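A Cyclobutyl Group in Place of Hydrogen on the Shared Core

A few compounds are considered here, and "the series" means these few. Any claim that something is new, unique, unknown or untested is made for them only; others in the source may bear on it.

Measured so far:
Compound 1, `CCCCOC(=O)NS(=O)(=O)c1ccc(CCC)cc1-c1ccc(Cn2c(C(C)C)nc3ccccc32)cc1`: 4 nM
Compound 2, `CCCCOC(=O)NS(=O)(=O)c1ccc(CCC)cc1-c1ccc(Cn2c(-c3ccccc3)nc3ccccc32)cc1`: 590 nM
Compound 3, `CCCCOC(=O)NS(=O)(=O)c1ccc(CCC)cc1-c1ccc(Cn2cnc3ccccc32)cc1`: 29 nM

All three were tested in an assay on membranes from HEK293 cells for displacement of a labelled ligand from Type-2 angiotensin II receptor (Homo sapiens), read by radioligand binding; a lower number here means a stronger inhibitor, a higher number a weaker inhibitor. Compound 3, which carries only hydrogen at the position in question, gives the second highest number of the three. Its nearest neighbour is compound 1: the step of a 7.3-fold higher number from compound 1 to compound 3 (0.86 log units; beyond the scatter) shows that removing the isopropyl group weakens binding modestly. At the other end, a 20-fold lower number from compound 2 to compound 3 (1.31 log units; beyond the scatter) shows that the phenyl group of compound 2 is much less favourable than hydrogen, and a 150-fold higher number from compound 1 to compound 2 (2.17 log units; beyond the scatter) shows the same contrast directly.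

Compound 4, `CCCCOC(=O)NS(=O)(=O)c1ccc(CCC)cc1-c1ccc(Cn2c(C3CCC3)nc3ccccc32)cc1`, is the next compound. The change is cyclobutyl in place of hydrogen on an aromatic carbon. A cyclobutyl group is a small non-aromatic ring of carbon only, a branched aliphatic group much like the isopropyl of compound 1 rather than the flat aromatic phenyl of compound 2. The most relevant measured step is therefore a 7.3-fold higher number from compound 1 to compound 3 (0.86 log units; beyond the scatter), read in reverse: putting a small branched alkyl group back at this place is expected to lower the number by a modest amount. The estimate for compound 4 is 7 nM, with a range of 2 nM to 40 nM, which corresponds to an expected step of a 4.1-fold lower number from compound 3 to compound 4 (0.62 log units; beyond the scatter).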

Compound 4, inhibition constant: 12 nM
Compound 4: the middle estimate sits 1.7-fold (0.23 log units) below what was measured, and the stated range covers the measured number.
By their numbers in this assay, from the lowest: compound 1; then compound 4; then compound 3; then compound 2.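

In this assay, the cyclobutyl group improves on hydrogen (a 2.4-fold lower number from compound 3 to compound 4 (0.38 log units; beyond the scatter)), so compound 1 no longer stands alone: two non-aromatic carbon groups at this position now give lower numbers than hydrogen. The two are not interchangeable, however, as closing the branched shape into a ring gives up part of what isopropyl offers (a 3.0-fold higher number from compound 1 to compound 4 (0.48 log units; beyond the scatter)), leaving compound 4 in the middle of the series. A ring at this position is also not enough on its own to explain the poor result of compound 2, since the non-aromatic ring does far better than the flat aromatic one (a 49-fold lower number from compound 2 to compound 4 (1.69 log units; beyond the scatter)), although nothing available here gives a reason for this order of the groups.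

The compounds shown leave open how other carbon groups would rank at this position, such as a cyclopropyl ring, a cyclopentyl ring or a straight propyl chain. They also leave open what would happen with a group carrying nitrogen or oxygen here, such as an amine or a hydroxyl, because every group so far is built from carbon alone.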